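The compounds below may be only part of what the source reports. "The series", "measured", "known", "first", "only" and "open" are said of these compounds alone.

Of the compounds shown here, three of a shared core have been measured in a functional assay on CHO cells for agonist activity at Free fatty acid receptor 1 (Homo sapiens), read by FLIPR and calcium flux, in the presence of a further agent that is not named here; on this read-out higher numbers stand for an effect only at larger amounts of compound and lower numbers for an effect already at smaller amounts. Compound 1 `O=C(O)CCc1ccc(OCc2ncc(-c3cccc(Cl)c3)o2)cc1` gives 47500 nM. Compound 2 `O=C(O)CCc1ccc(OCc2coc(-c3ccccc3)n2)cc1` gives 700 nM, and compound 3 `O=C(O)CCc1ccc(OCc2nc(-c3ccc(F)cc3)no2)cc1` gives 680 nM. Compound 3 thus carries the lowest of the three numbers, but its gap to compound 2 lies within the scatter, so the two cannot be told apart, while compound 1 stands well beyond the scatter from both.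

The next step leads from compound 3 to compound 4 `O=C(O)CCc1ccc(OCc2nc(-c3ccco3)no2)cc1`. The structural change is furan-2-yl in place of 4-fluorophenyl on an aromatic carbon, the carbon that sits between two ring nitrogen atoms of the five-membered aromatic ring with two nitrogen and one oxygen. Among the measured compounds shown here, no measured pair among the three compounds mirrors this exchange, so there is no step to lean on. A smaller ring with one hetero atom replaces a six-membered carbon ring, and the weakening seen in compound 1 shows how much the outer ring can matter. A moderate loss, somewhat beyond the scatter, is expected as the step of a 2.2-fold higher number from compound 3 to compound 4 (0.34 log units; beyond the scatter). Compound 4 is therefore estimated at 1500 nM, with a range from 500 nM to 5000 nM.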

Compound 4, half-maximal effective concentration: > 100000 nM
Compound 4 ended at the assay's limit (the forecaster's own chance of this, stated with the estimate: 10%); at least 66-fold (1.82 log units) between middle value and limit.
By their numbers in this assay, from the lowest: compounds 3 and 2 (each within the scatter of the next); then compound 1. At a limit, above all of these: compound 4.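

In this assay, the group on the aromatic carbon between two ring nitrogen atoms proves far from interchangeable: furan-2-yl in place of 4-fluorophenyl brings an at least 140-fold higher number from compound 3 to compound 4 (2.16 log units; beyond the scatter). Compound 4 gives > 100000 nM, which is a limit of the assay and not a number. This is the first step here between two compounds that differ in only one place, so it ties a large change in the read-out directly to this position, although its true size stays open since the value sits at the end of the measurable range: the limit of > 100000 nM in this assay, at which 1 of the 4 values shown sits.

The change alters two things at once, replacing a six-membered carbon ring with a five-membered ring that holds a hetero atom, and the compounds shown cannot separate these two differences or say whether the loss comes from either one. A thiophen-2-yl group at this carbon would keep the five-membered ring with a sulfur atom in place of the oxygen, and a pyridin-2-yl group would keep the six-membered ring while adding a ring nitrogen, so either would help to show which difference matters.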